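Chloro Addition Weighed Against One Measured Precedent

A few compounds are considered here, and "the series" means these few. Any claim that something is new, unique, unknown or untested is made for them only; others in the source may bear on it.

Compound 1 `Clc1ccc(-c2nnc(C(NCc3ccccc3)c3ccc[nH]3)o2)cc1` gives 46200 nM in a functional assay on MCF7 cells (Homo sapiens) for cytotoxicity, read by MTT assay, with a stated time of 24 h; on this read-out lower numbers stand for stronger inhibition and higher numbers for weaker inhibition. Compound 2 `Clc1ccc(-c2nnc(C(NCc3ccccc3)c3ccc[nH]3)o2)cc1Cl` gives 13900 nM in this assay, and the step of a 3.3-fold lower number from compound 1 to compound 2 (0.52 log units; beyond the scatter) came from the change (chloro in place of hydrogen on an aromatic carbon). Compound 3 `COc1ccc(CNC(c2ccc[nH]2)c2nnc(-c3ccccc3)o2)cc1` gives 142000 nM in this assay, the highest of the three numbers. The difference between the cores of compound 1 and compound 3 is not broken down here. Compound 4 `COc1ccc(CNC(c2ccc[nH]2)c2nnc(-c3cccc(Cl)c3)o2)cc1` is not yet measured; it differs from compound 3 by chloro in place of hydrogen on an aromatic carbon. This is the same kind of change as that from compound 1 to compound 2, but in compound 2 the entering chloro sits ortho to a chloro group, whereas in compound 4 the place is meta to a large group only. Because the earlier step of a 3.3-fold lower number from compound 1 to compound 2 (0.52 log units; beyond the scatter) was modest and the surroundings differ, the step from compound 3 to compound 4 is expected to be a 2.6-fold lower number from compound 3 to compound 4 (0.41 log units; beyond the scatter), somewhat smaller. Compound 4 is expected to give about 55000 nM in this assay, between 25000 nM and 120000 nM.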

Compound 4, half-maximal inhibitory concentration: 41700 nM
The estimate for compound 4 lay 1.3-fold (0.12 log units) above the measured number, and the stated range covers the measured number.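

In this assay the chloro change gave a 3.4-fold lower number from compound 3 to compound 4 (0.53 log units; beyond the scatter), and it carried over from one core to the other at much the same size: the same change on two cores in this assay, a 3.3-fold lower number (0.52 log units; beyond the scatter) from compound 1 to compound 2 and a 3.4-fold lower number (0.53 log units; beyond the scatter) from compound 3 to compound 4, 1.0-fold (0.01 log units) apart, within the scatter of two such steps. For the compounds shown here, this agreement rests on only two pairs of compounds, so it supports carrying the change between these two cores and no further. It does not show that the step would hold on any other core or at any other place on the ring, and it does not explain why the two steps match.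

The compounds shown leave open whether fluoro, a nitrile or an amine at that place would lower the number as chloro does. They also leave open whether a second chloro on the 3-chlorophenyl ring of compound 4 would lower it further.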